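Acrylamide side-chain variations on a shared thienopyrimidine-free core series

The source may report more compounds than this note shows. Statements on the series, on what has been measured and on what is new or still open speak of the compounds shown alone.

Measured so far:
compound 1, `C=CC(=O)Nc1cccc(Oc2nc(Nc3cccc(C#N)c3)nc3ccsc23)c1` — 4340 nM
compound 2, `CC/C=C/C(=O)Nc1cccc(Oc2nc(Nc3cccc(C#N)c3)nc3ccsc23)c1` — 14900 nM
compound 3, `CC(C)/C=C/C(=O)Nc1cccc(Oc2nc(Nc3cccc(C#N)c3)nc3ccsc23)c1` — 19000 nM

The numbers come from a functional assay on A549 cells (Homo sapiens) for inhibition, read by MTT assay, with a stated time of 72 h; a lower number here means a stronger inhibitor, a higher number a weaker inhibitor. Compound 3 gives the highest number recorded so far in this assay; its nearest neighbour is compound 2, and the gap between them, a 1.3-fold higher number from compound 2 to compound 3 (0.11 log units; within the scatter), is within the scatter, so no order between the two can be claimed. The distance to compound 1 is larger: a 4.4-fold higher number from compound 1 to compound 3 (0.64 log units; beyond the scatter) is beyond the scatter, as is a 3.4-fold higher number from compound 1 to compound 2 (0.54 log units; beyond the scatter).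

Compound 4, `CCC/C=C/C(=O)Nc1cccc(Oc2nc(Nc3cccc(C#N)c3)nc3ccsc23)c1`, carries the change (propyl in place of isopropyl on a double-bonded chain carbon bound to a double-bonded chain carbon), so that 3-methylbut-1-en-1-yl becomes pent-1-en-1-yl on the carbonyl; the two compounds have the same atoms, joined differently. Within the data shown here, the only measured step that touches this part of the molecule without changing the chain length is a 1.3-fold higher number from compound 2 to compound 3 (0.11 log units; within the scatter), which stayed within the scatter. Rearranging the same three carbons from isopropyl to propyl is therefore expected to give no step beyond the scatter in this assay, estimated as a 1.1-fold lower number from compound 3 to compound 4 (0.05 log units; within the scatter).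

Compound 4 is estimated at 17000 nM, with a range from 8000 nM to 40000 nM.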

Compound 4, half-maximal inhibitory concentration: 16700 nM
Estimate against measurement, compound 4: 1.0-fold (0.01 log units) above, within the range that was stated.
By their numbers in this assay, from the lowest: compound 1; then compounds 2, 4 and 3 (each within the scatter of the next).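

In this assay, the straight propyl and the branched isopropyl on this double-bonded chain carbon cannot be told apart, with a 1.1-fold lower number from compound 3 to compound 4 (0.06 log units; within the scatter). Adding a methyl to the saturated chain of compound 2 also leaves the number within the scatter, with a 1.1-fold higher number from compound 2 to compound 4 (0.05 log units; within the scatter), so neither branching nor this extension separates compounds 2, 3 and 4. Among these compounds, the only step beyond the scatter here is the one from vinyl to pent-1-en-1-yl on the carbonyl carbon, with a 3.8-fold higher number from compound 1 to compound 4 (0.59 log units; beyond the scatter), and no measurement bearing on the reason for these numbers is available.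

On these data alone, it remains open whether a longer chain, such as hept-1-en-1-yl, would stay level with compounds 2, 3 and 4. The same question applies to an amine, such as a dimethylaminomethyl group, on the same double-bonded chain carbon.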